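The compounds below may be only part of what the source reports. "The series", "measured", "known", "first", "only" and "open" are said of these compounds alone.

Three members of the series have been measured in an ADME assay on liver (Homo sapiens) for metabolic stability, read by LC-MS, using S9 fraction and NADPH, with a stated time of 45 min, tested at 1 uM; a lower number here means that the compound disappears faster, a higher number that the compound lasts longer. Compound 1 `CCNC(=O)c1cc(N)c(Nc2ccc(C#N)cc2)cc1Oc1c(C)cc(/C=C/C#N)cc1C` gives 1.02 h. Compound 2 `Cc1cc(/C=C/C#N)cc(C)c1Oc1cc(Nc2ccc(C#N)cc2)c(N)cc1C(=O)NN` gives 0.65 h. Compound 3 `Cc1cc(/C=C/C#N)cc(C)c1Oc1cc(Nc2ccc(C#N)cc2)c(N)cc1C(N)=O` gives 1.8 h. On the numbers shown compound 3 stands at the top, but a 1.8-fold higher number from compound 1 to compound 3 (0.25 log units; within the scatter) lies within the scatter, so compound 1 and compound 3 cannot be separated; only a 2.8-fold higher number from compound 2 to compound 3 (0.44 log units; beyond the scatter) reaches beyond it, and a 1.6-fold lower number from compound 1 to compound 2 (0.20 log units; within the scatter) stays within it.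

Compound 4 `CNC(=O)c1cc(N)c(Nc2ccc(C#N)cc2)cc1Oc1c(C)cc(/C=C/C#N)cc1C` differs from compound 3 by methyl in place of hydrogen on an amide-type nitrogen. Within the data shown here, the step that bears on this is the one from compound 1 to compound 3, where an ethyl group left the same amide-type nitrogen and the number moved by a 1.8-fold higher number from compound 1 to compound 3 (0.25 log units; within the scatter), within the scatter. A methyl group reinstates part of that substituent, so a step in this assay of at most that size, and in the opposite direction, is expected, most likely not beyond the scatter. Compound 4 is therefore estimated at 1.3 h, with a range of 0.7 h to 2.4 h, which means an expected step of a 1.4-fold lower number from compound 3 to compound 4 (0.14 log units; within the scatter).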

Compound 4, half-life in the liver assay: 1.6 h
Compound 4: the middle estimate sits 1.2-fold (0.09 log units) below what was measured, within the range that was stated.
By their numbers in the liver assay, from the lowest: compounds 2, 1, 4 and 3 (each within the scatter of the next, the first and the last beyond it).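

In the liver assay, methyl on the amide-type nitrogen brings no readable change, a 1.1-fold lower number from compound 3 to compound 4 (0.05 log units; within the scatter), and the shorter chain brings none either, a 1.6-fold higher number from compound 1 to compound 4 (0.20 log units; within the scatter), so compound 1, compound 3 and compound 4 cannot be separated and this nitrogen carries hydrogen, methyl or ethyl alike. Amino stands apart from methyl, a 2.5-fold higher number from compound 2 to compound 4 (0.39 log units; beyond the scatter), though compound 2 remains within the scatter of compound 1. In a physicochemical assay for lipophilicity, read by HPLC, measured as octanol-water partition, with a stated time of 24 h, at pH 7.4 (a higher number here means a more lipophilic compound, a lower number a more polar compound), compound 3 gives 3.53 and compound 4 gives 2.65, a number 0.88 log units lower from compound 3 to compound 4 (beyond the scatter), so the same change that leaves the half-life unresolved moves the partition coefficient beyond the scatter.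

Open, from the compounds shown here alone, is whether a longer chain, a hydroxyethyl group or a carboxylic acid on this nitrogen would keep the half-life in this band. Also open, going by these compounds, is whether the partition coefficient would follow the direction seen with methyl.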